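Moving the pyrazole attachment point in compound 1

The source may hold more compounds than are shown below. What is called first, only, known or untested is meant among the compounds shown, and "the series" means these compounds.

Within the data shown here, compound 1 `c1cc(-c2cn[nH]c2)c2c(c1)C(c1ncc[nH]1)CC2` is the only member of this set with a measured number: in a functional assay on CHO cells for agonist activity at Alpha-1D adrenergic receptor (Homo sapiens), read by FLIPR and calcium flux (on this read-out higher numbers stand for an effect only at larger amounts of compound and lower numbers for an effect already at smaller amounts), compound 1 gives 319 nM. Compound 2 `Cc1ccc2c(c1NS(C)(=O)=O)CCC2c1ncc[nH]1` reaches only the limit of the assay, and in this assay compound 2 gives > 10000 nM, which is a limit rather than a number. Compound 3 `Cn1ccc(-c2cccc3c2CCC3c2ncc[nH]2)n1` likewise sits at the limit, and in this assay compound 3 gives > 10000 nM, again a limit. Among the measured compounds shown here, the one measured step that touches the pyrazole, an at least 31-fold higher number from compound 1 to compound 3 (1.49 log units; beyond the scatter), is large; it also bears on compound 4 `c1cc(-c2ccn[nH]2)c2c(c1)C(c1ncc[nH]1)CC2`, whose change from compound 1 is 1H-pyrazol-5-yl in place of 1H-pyrazol-4-yl on an aromatic carbon. That step, however, alters both the attachment point and the ring nitrogen substitution, whereas compound 4 keeps the bare ring, so the expected loss is smaller and uncertain. An expected step of a 7.8-fold higher number from compound 1 to compound 4 (0.89 log units; beyond the scatter) follows for compound 4 in this assay. Compound 4 is therefore estimated at 2500 nM, in a range from 500 nM to 12000 nM.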

Compound 4, half-maximal effective concentration: 336 nM
The estimate for compound 4 lay 7.4-fold (0.87 log units) above the measured number; measured number outside the range, below it.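

In this assay, moving the attachment point of the unsubstituted pyrazole leaves the read-out unchanged: a 1.1-fold higher number from compound 1 to compound 4 (0.02 log units; within the scatter). On this aromatic carbon of the shared core, 1H-pyrazol-5-yl and 1H-pyrazol-4-yl therefore read alike, so the attachment point alone does not account for the large step seen earlier, which now stands against a second exchange, 1H-pyrazol-5-yl in place of 1-methyl-1H-pyrazol-3-yl: an at least 29-fold lower number from compound 3 to compound 4 (1.47 log units; beyond the scatter). That step is open-ended, as compound 3 gives a limit and not a number: the limit of > 10000 nM in this assay, at which 2 of the 4 values shown sit.

The compounds shown leave open whether the methyl group on the ring nitrogen by itself accounts for that step. They also do not tell how an amine or a carboxylic acid on the pyrazole, or a longer chain on its nitrogen, would read in this assay.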